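The source may hold more compounds than are shown below. What is called first, only, known or untested is meant among the compounds shown, and "the series" means these compounds.

Compound 1 `Oc1ccc(-c2cc(-c3ccccc3F)cc(-c3ccccc3O)n2)cc1`, compound 2 `Oc1ccc(-c2cc(-c3ccccc3F)cc(-c3ccc(O)cc3)n2)cc1` and compound 3 `Oc1ccc(-c2cc(-c3cccc(F)c3)cc(-c3ccc(O)cc3)n2)cc1` share one core and differ only in where the hydroxyl and fluoro substituents sit on its aryl groups. In a functional assay on DU-145 cells (Homo sapiens) for inhibition (on this read-out lower numbers stand for stronger inhibition and higher numbers for weaker inhibition), compound 1 gives only a limit of the assay, > 50000 nM. Compound 2 gives 7780 nM and compound 3 gives 9290 nM. The step of an at least 6.4-fold lower number from compound 1 to compound 2 (0.80 log units; beyond the scatter) is the one clear change among these three, whereas a 1.2-fold higher number from compound 2 to compound 3 (0.08 log units; within the scatter) stays within the scatter. Compound 2 therefore holds the lower of the two numbers shown, with compound 3 within the scatter of it and compound 1 represented only by a limit.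

Compound 4 `Oc1ccc(-c2cc(-c3ccccc3OC(F)(F)F)cc(-c3ccc(O)cc3)n2)cc1` departs from compound 2 by trifluoromethoxy in place of fluoro on an aromatic carbon. Going by the values given here, only one measured step touches the fluoro group at all, namely a 1.2-fold higher number from compound 2 to compound 3 (0.08 log units; within the scatter), which did not move the read-out beyond the scatter; no measured step exchanges fluoro for a larger group. On these data alone, the change is consequently expected to produce no step beyond the scatter, a 1.3-fold higher number from compound 2 to compound 4 (0.11 log units; within the scatter), with the range widened because the entering group is untested here. Compound 4 is expected at 10000 nM, between 3000 nM and 35000 nM.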

Compound 4, half-maximal inhibitory concentration: 16000 nM
Compound 4: middle estimate off by 1.6-fold (0.20 log units), on the low side, within the range that was stated.
By their numbers in this assay, from the lowest: compounds 2, 3 and 4 (each within the scatter of the next, the first and the last beyond it). At a limit, above all of these: compound 1.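

At this place, ortho to a large group, the read-out in this assay depends on which substituent is present: trifluoromethoxy in place of fluoro gives a 2.1-fold higher number from compound 2 to compound 4 (0.31 log units; beyond the scatter). The earlier compounds shown here had only moved the fluoro group, which gave a 1.2-fold higher number from compound 2 to compound 3 (0.08 log units; within the scatter). Going by these compounds alone, this is therefore the first change to that substituent to go beyond the scatter, though the step is modest and runs towards weaker inhibition, and nothing measured here gives a cause for it.

The compounds shown leave open whether methoxy, chloro, an amine or a carboxylic acid in place of fluoro would stay close to compound 2 or move further from it. They also leave open whether trifluoromethoxy would give a similar result at the place the fluoro group holds in compound 3.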